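The compounds below may be only part of what the source reports. "The series", "measured", "known", "first", "only" and "open" are said of these compounds alone.

In a functional assay on MCF7 cells (Homo sapiens) for antiproliferative activity, read by CellTiter-Glo, with a stated time of 5 days (a lower number here means a stronger inhibitor, a higher number a weaker inhibitor), compound 1 `CC/C(=C(/c1ccc(/C=C/C(=O)O)cc1)c1ccc2scnc2c1)c1ccccc1` gives 90 nM and compound 3 `CC/C(=C(/c1ccc(/C=C/C(=O)O)cc1)c1ccc(-c2cncs2)cc1)c1ccccc1` gives 31 nM, the lower of the two numbers. Compound 2 `CC/C(=C(/c1ccc(/C=C/C(=O)O)cc1)c1ccc2ocnc2c1)c1ccccc1` gives > 500 nM, which is a limit of the assay and not a number. Compound 4 `CC/C(=C(/c1ccc(/C=C/C(=O)O)cc1)c1ccc(N2CCCCC2)cc1)c1ccccc1` carries piperidin-1-yl in place of 1,3-thiazol-5-yl on an aromatic carbon. Among the measured compounds shown here, no measured step makes this exact exchange. The nearest guide is the swap of 1,3-benzothiazol-5-yl for 1,3-benzoxazol-5-yl, which gave an at least 5.5-fold higher number from compound 1 to compound 2 (0.74 log units; beyond the scatter), so replacing one ring with another can clearly cost activity. In this assay, the expected change is a moderate rise, a 2.9-fold higher number from compound 3 to compound 4 (0.46 log units; beyond the scatter), though with wide uncertainty. The estimate for compound 4 is 90 nM, with an expected range of 20 nM to 400 nM.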

Compound 4, half-maximal inhibitory concentration: 450 nM
Compound 4: the middle estimate sits 5.0-fold (0.70 log units) below what was measured; measured number above the stated range.
By their numbers in this assay, from the lowest: compound 3; then compound 1; then compound 4. At a limit, above all of these: compound 2.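

In this assay, the aromatic carbon para to a large group proves sensitive to what it carries: piperidin-1-yl in place of 1,3-thiazol-5-yl gives a 15-fold higher number from compound 3 to compound 4 (1.16 log units; beyond the scatter). For this pair, a six-membered non-aromatic ring does far worse than a five-membered aromatic one. Compound 4 still gets a number, though not far short of the limit reached by compound 2: the limit of > 500 nM in this assay, at which 1 of the 4 values shown sits.

This single pair cannot separate the loss of aromatic character from the change in ring size or hetero atoms. Going by these compounds, how a phenyl ring or a morpholin-4-yl group on this carbon would compare remains open.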